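Swapping the anilino aryl group: compound 3 expected

The compounds below may be only part of what the source reports. "The series", "measured", "known", "first", "only" and "open" are said of these compounds alone.

Compound 1, `COc1cc(/C=C/C(=O)c2sc(Nc3ccc(Cl)cc3)nc2C)cc(OC)c1OC`, gives > 25000 nM in a functional assay on BGC-823 cells (Homo sapiens) for cytotoxicity, read by MTT assay; on this read-out higher numbers stand for weaker inhibition and lower numbers for stronger inhibition.
Compound 2, `Cc1nc(Nc2ccc(Cl)c(Cl)c2)sc1C(=O)/C=C/c1ccc(Cl)cc1`, gives 22700 nM in this assay.

The value of compound 1 is a limit of this assay, not a number, and it sits at the limit of > 25000 nM in this assay, at which 1 of the 2 values shown sits. Compound 2 is also weak. Compound 3, `COc1cc(/C=C/C(=O)c2sc(Nc3ccccc3C)nc2C)cc(OC)c1OC`, carries 2-methylphenyl in place of 4-chlorophenyl on a nitrogen on an aromatic ring. For the measured compounds named here, no measured pair shows this change, so a step within the scatter, in no clear direction, is expected. Compound 3 is estimated at 25000 nM in this assay, within 8000 nM to 80000 nM. The expected step of a number no higher from compound 1 to compound 3 (the limit leaves the size open) stays within the scatter.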

Compound 3, half-maximal inhibitory concentration: 5400 nM
Estimate against measurement, compound 3: 4.6-fold (0.67 log units) above, and the stated range ends above it.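

In this assay, 2-methylphenyl in place of 4-chlorophenyl on the nitrogen brings a clear gain (an at least 4.6-fold lower number from compound 1 to compound 3 (0.66 log units; beyond the scatter)). For the compounds shown here, this shows that the aryl group at this position can change cytotoxicity, which the earlier compounds could not show. From the compounds shown here alone, compound 1 has a limit of the assay rather than a number, and the true size of the step stays open because of that limit: the limit of > 25000 nM in this assay, at which 1 of the 3 values shown sits.

The change removes the chlorine and adds a methyl at once, so the part each plays remains unclear. Plain phenyl, 2-chlorophenyl and 4-methylphenyl would help separate the two.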